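Three Weak Analogues and One Untested Variant

This account rests on a few compounds, and the source may have more. Where it says the series, first, only, none or still open, it means among the compounds named here.

Of the compounds shown here, three have been tested in a functional assay on PC-3 cells (Homo sapiens) for inhibition, read by sulforhodamine B assay, with a stated time of 48 h (a lower number here means a stronger inhibitor of growth, a higher number a weaker inhibitor of growth), so far, and none gave a measurable number. Compound 1 `COC1=C[C@H](O)[C@H](C/C=C(\C)CC/C=C(\C)C[C@@H]2C[C@@H](C)C(=O)O2)[C@@H](C)C1=O` reached only the limit of the assay, > 30000 nM. Compound 2 `COC1=C(OC)[C@H](O)[C@H](C/C=C(\C)CC/C=C(\C)C[C@H](O)/C=C(\C)CO)[C@@H](C)C1=O` likewise stopped at the limit, > 30000 nM. Compound 3 `COC1=C(OC)[C@H](OC(C)=O)[C@H](C/C=C(\C)CC/C=C(\C)C[C@H](O)/C=C(\C)C(=O)O)[C@@H](C)C1=O` also sits at the limit, > 30000 nM. Compound 3 therefore stands nowhere apart from the others: all three values are limits, a point made plain by the limit of > 30000 nM in this assay, at which 3 of the 3 values shown sit, so no order among them can be read.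

The next compound, compound 4 `COC1=C(OC)[C@H](OC(C)=O)[C@H](C/C=C(\C)CC/C=C(\C)C[C@H](O)C=C(C)C)[C@@H](C)C1=O`, has not yet been measured in this assay. It differs from compound 3 in a single place: 2-methylprop-1-en-1-yl in place of 2-carboxyprop-1-en-1-yl on a saturated chain carbon bound to an oxygen on a saturated carbon and a saturated chain carbon. Since every step between measured compounds is a limit to a limit, nothing measured shows how this kind of change moves growth inhibition, in either direction. The only reasonable expectation is that compound 4 stays close to where compound 3 sits, with the step of a number no higher from compound 3 to compound 4 (the limit leaves the size open) expected to be no larger than the usual scatter. On that basis, compound 4 is estimated at 30000 nM in this assay, with a range from 6000 nM to 150000 nM, and a real chance that the assay again reports only its limit.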

Compound 4, concentration for 50% growth inhibition: > 30000 nM
Compound 4 ended at the assay's limit; the forecaster's own chance of this, stated with the estimate: 60%; the middle value lies on the limit itself.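

In this assay compound 4 gives only a limit, > 30000 nM. Compound 3 also stopped at a limit, so the step between compound 3 and compound 4 cannot be read. The compounds shown leave open how these four rank and which change, if any, would bring growth inhibition to a measurable number: the limit of > 30000 nM in this assay, at which 4 of the 4 values shown sit.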